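A few compounds are considered here, and "the series" means these few. Any claim that something is new, unique, unknown or untested is made for them only; others in the source may bear on it.

Compound 1 `CCCCCCCCCCCOC(=O)CCC(=O)N1CCN(CCCOc2cc3c(Nc4ccc(F)c(Cl)c4)ncnc3cc2OC)CC1` and compound 2 `CCCCCCCCCCCCOC(=O)CCC(=O)N1CCN(CCCOc2cc3c(Nc4ccc(F)c(Cl)c4)ncnc3cc2OC)CC1` share one core and differ only along the saturated chain. In a functional assay on A549 cells (Homo sapiens) for cytotoxicity, read by MTT assay, with a stated time of 24 h, tested at 60 uM (on this read-out lower numbers stand for a stronger effect and higher numbers for a weaker effect at the one concentration tested), compound 1 gives 3.9%, and in this assay compound 2 gives 2%. The step of a number 1.9 percentage points lower from compound 1 to compound 2 (within the scatter) lies within the scatter, so the two compounds cannot be separated on these numbers; compound 2 holds the smaller of the two numbers, with compound 1 nearest to it. Within the data shown here, compound 3 `CCCCCCCCCCCCCCCOC(=O)CCC(=O)N1CCN(CCCOc2cc3c(Nc4ccc(F)c(Cl)c4)ncnc3cc2OC)CC1` is the next member of the series. propyl in place of hydrogen on a saturated chain carbon, ten or more bonds along the chain from an oxygen next to a carbonyl group The only measured step on this part of the structure, a number 1.9 percentage points lower from compound 1 to compound 2 (within the scatter), was within the scatter, so an extension of the same kind by propyl is expected to leave the read-out where it is, with no step beyond the scatter in this assay. The expected step of no change at the digits printed from compound 2 to compound 3 (within the scatter) is small. Compound 3 is therefore estimated at 2%, with a range from 0% to 12%.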

Compound 3, a percentage reported as activity, at one concentration (the size of the read-out at that concentration, not a potency): 81.6%
Estimate against measurement, compound 3: 79.6 percentage points below; the whole stated range lies below it.
By their numbers in this assay, from the lowest: compounds 2 and 1 (each within the scatter of the next); then compound 3.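

Extension at this saturated chain carbon is not uniformly tolerated in this assay: propyl in place of hydrogen gives a number 79.6 percentage points higher from compound 2 to compound 3 (beyond the scatter) and butyl in place of hydrogen gives a number 77.7 percentage points higher from compound 1 to compound 3 (beyond the scatter), so the read-out at this position can move far towards a weaker effect. Across these three compounds the response is not graded with chain size, since compound 1 and compound 2 cannot be separated, while compound 3 stands apart from both. No available evidence bears on what underlies this large step.

Still open, as far as these compounds go, is where between compound 2 and compound 3 the change sets in, with ethyl in place of hydrogen as the obvious intermediate. Also open, from the compounds shown here alone, is whether a longer chain stays at the level of compound 3, and whether a chain ending in a carboxylic acid or an amine behaves likewise.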